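Swapping trifluoromethyl for chloro on the urea aryl ring

This account rests on a few compounds, and the source may have more. Where it says the series, first, only, none or still open, it means among the compounds named here.

Measured compounds:
- compound 1, `O=C(Nc1cccc(-n2cc(-c3ccncc3)c(-c3cc(O)cc(Cl)c3)n2)c1)Nc1ccc(Cl)c(C(F)(F)F)c1`: 83%
- compound 2, `O=C(Nc1cccc(-n2cc(-c3ccncc3)c(-c3cc(O)cc(Cl)c3)n2)c1)Nc1ccc(Cl)c(Cl)c1`: 92%
- compound 3, `COc1cc(Cl)cc(-c2nn(-c3cccc(NC(=O)Nc4ccc(Cl)c(C(F)(F)F)c4)c3)cc2-c2ccncc2)c1`: 77%

Of the compounds shown here, three have been tested in a functional assay on NCI-H522 cells (Homo sapiens) for inhibition, read by sulforhodamine B assay, with a stated time of 48 h, tested at 0.1 uM; on this read-out lower numbers stand for a stronger effect and higher numbers for a weaker effect at the one concentration tested. Compound 3 stands lowest of the three numbers; its nearest neighbour is compound 1, a number a number 6 percentage points lower from compound 1 to compound 3 (within the scatter), a step that stays within the scatter, while compound 2 lies further off, with the gap between compound 3 and compound 2 reaching beyond the scatter.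

Compound 4, `COc1cc(Cl)cc(-c2nn(-c3cccc(NC(=O)Nc4ccc(Cl)c(Cl)c4)c3)cc2-c2ccncc2)c1`, has not yet been measured. It differs from compound 3 in one place: chloro in place of trifluoromethyl on an aromatic carbon. The same change has already been seen once, from compound 1 to compound 2, where the number was a number 9 percentage points higher from compound 1 to compound 2 (within the scatter). Among the measured compounds shown here, no other measured step bears on this change. On that single precedent compound 4 is expected to come out close to compound 3 in this assay, with any shift sitting within the scatter, an expected step of a number 8 percentage points higher from compound 3 to compound 4 (within the scatter). Compound 4 is therefore estimated at 85%, with a likely range from 72% to 98%.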

Compound 4, a percentage reported as activity, at one concentration (the size of the read-out at that concentration, not a potency): 53%
Compound 4: middle estimate off by 32 percentage points, on the high side; the measured number lies below the stated range.
By their numbers in this assay, from the lowest: compound 4; then compounds 3, 1 and 2 (each within the scatter of the next, the first and the last beyond it).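

The swap of chloro for trifluoromethyl at this position had stayed within the scatter on the core with the free hydroxyl, but with a methyl on that oxygen it gives a number 24 percentage points lower from compound 3 to compound 4 (beyond the scatter), so the change does not carry over from one core to the other: the same change on two cores in this assay, a number 9 percentage points higher (within the scatter) from compound 1 to compound 2 and a number 24 percentage points lower (beyond the scatter) from compound 3 to compound 4, 33 percentage points apart, beyond the scatter of two such steps

Read the other way, methyl in place of hydrogen on that oxygen gives a number 39 percentage points lower from compound 2 to compound 4 (beyond the scatter) with the 3,4-dichlorophenyl group, whereas it stayed within the scatter with the 4-chloro-3-(trifluoromethyl)phenyl group: the same change on two cores in this assay, a number 6 percentage points lower (within the scatter) from compound 1 to compound 3 and a number 39 percentage points lower (beyond the scatter) from compound 2 to compound 4, 33 percentage points apart, beyond the scatter of two such steps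

The two places therefore do not act independently in this assay.

As far as these compounds go, whether this dependence extends to a longer chain on that oxygen, such as ethyl, or to bromo or nitrile in place of the chloro on the urea aryl ring stays open. Each compound was read at a single concentration, so the compounds shown give no potency and no cause for the interplay.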